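The source may report more compounds than this note shows. Statements on the series, on what has been measured and on what is new or still open speak of the compounds shown alone.

Of the compounds shown here, three with a shared core have been tested in a functional assay on MCF7 cells (Homo sapiens) for antiproliferative activity, read by MTT assay, with a stated time of 72 h (on this read-out lower numbers stand for stronger inhibition and higher numbers for weaker inhibition), so far: compound 1 (`COc1cc(-c2ncnn2-c2cccc(F)c2)cc(OC)c1OC`), compound 2 (`COc1cc(-c2ncnn2-c2ccc(Cl)cc2Cl)cc(OC)c1OC`) and compound 3 (`COc1cc(-c2ncnn2-c2ccc(F)cc2)cc(OC)c1OC`). Compound 1 gives > 10000 nM and that is a limit of the assay, not a number. Compound 2 gives > 10000 nM and that is again a limit. Compound 3 gives > 10000 nM and this too is a limit, not a number. Among the compounds with values here, the whole set stands at one mark, namely the limit of > 10000 nM in this assay, at which 3 of the 3 values shown sit, and no compound can be ranked against another. Compound 4 (`COc1cc(-c2ncnn2-c2ccc([N+](=O)[O-])cc2)cc(OC)c1OC`) has nitro in place of fluoro on an aromatic carbon, para to a large group (nitro in place of fluoro on an aromatic carbon). The nearest evidence is a step that the two limits leave unreadable from compound 1 to compound 3 and, with it, a step that the two limits leave unreadable from compound 1 to compound 2 and a step that the two limits leave unreadable from compound 2 to compound 3 on the same aromatic nitrogen. None of these gives a size, and none involves a nitro group, so no direction can be argued. The expected change is a step that the limit leaves unreadable from compound 3 to compound 4 and it is not expected to exceed the scatter. For compound 4 the estimate is 20000 nM with an expected range from 8000 nM to 60000 nM and quite possibly another limit.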

Compound 4, half-maximal inhibitory concentration: > 10000 nM
Compound 4: a limit, no number; the forecaster's own chance of this, stated with the estimate: 80%; the middle value lies beyond the limit too.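

Compound 4 gives a limit, not a number, just as compound 3 does, so no step between compound 3 and compound 4 can be read: the limit of > 10000 nM in this assay, at which 4 of the 4 values shown sit.

The compounds shown leave open how strongly any of them acts and whether any other group on the shared core would give a measurable value.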